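A few compounds are considered here, and "the series" means these few. Any claim that something is new, unique, unknown or untested is made for them only; others in the source may bear on it.

Series notes, cytotoxicity. Of the compounds shown here, three of the shared core have been measured in an ADME assay on Vero cells (Chlorocebus sabaeus) for cytotoxicity; on this read-out higher numbers stand for lower toxicity in this test and lower numbers for higher toxicity in this test. Compound 1 `CCCCCCCCc1cc(-c2cn([C@H]3C[C@H](O)[C@@H](CO)O3)c(=O)[nH]c2=O)on1` gives 3000 nM in this assay. Compound 2 `CC(=O)OC[C@H]1O[C@@H](n2cc(-c3cc(C)no3)c(=O)[nH]c2=O)C[C@@H]1OC(C)=O` gives 3000 nM in this assay, and compound 3 `CCCc1cc(-c2cn([C@H]3C[C@H](OC(C)=O)[C@@H](COC(C)=O)O3)c(=O)[nH]c2=O)on1` gives 3000 nM in this assay. Compound 3 thus stands level with compounds 1 and 2 at the digits shown; its nearest neighbour is compound 1 and its furthest compound 2, and neither gap goes beyond the scatter. Among the compounds with values here, the single one-point step inside the measured set, no change at the digits printed from compound 2 to compound 3 (within the scatter), brings ethyl in place of hydrogen on a saturated chain carbon bound to an aromatic carbon and leaves the read-out unchanged within the scatter.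

Compound 4 `CCc1ccc(-c2cc(-c3cn([C@H]4C[C@H](OC(C)=O)[C@@H](COC(C)=O)O4)c(=O)[nH]c3=O)on2)cc1` has not been measured. It differs from compound 3 as follows: 4-ethylphenyl in place of propyl on an aromatic carbon. Within the data shown here, the only measured step that bears on this change is no change at the digits printed from compound 2 to compound 3 (within the scatter), a smaller change that was flat; no measured step brings an aromatic ring into the place concerned. With every measured value at the same level, the step expected for no change at the digits printed from compound 3 to compound 4 (within the scatter) is none beyond the scatter. Compound 4 is therefore estimated at 3000 nM in this assay, with a range of 1000 nM to 7000 nM.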

Compound 4, half-maximal cytotoxic concentration: 3000 nM
Estimate against measurement, compound 4: no gap at the digits printed; low and high end bracket the measured number.
By their numbers in this assay, from the lowest: compounds 1, 2, 3 and 4 (each within the scatter of the next).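

In this assay, within the data shown here, the aromatic carbon next to the ring nitrogen of the five-membered aromatic ring now carries an aromatic ring for the first time, and no change at the digits printed from compound 3 to compound 4 (within the scatter) is what 4-ethylphenyl in place of propyl gives. Read against methyl at the same place, no change at the digits printed from compound 2 to compound 4 (within the scatter) holds for 4-ethylphenyl as well, so methyl, propyl and 4-ethylphenyl, the last with its six-membered aromatic ring of carbon only, all sit at one level across compounds 2, 3 and 4. Nothing available explains this flat result.

Going by these compounds, since every value shown stands at one level, it remains open whether any group at this place moves the read-out at all, for instance an amine or a carboxylic acid carried on the phenyl ring, or a pyridine ring in place of the phenyl ring. Also open, on these data alone, is whether 4-ethylphenyl would read the same on the core of compound 1, which has free hydroxyl groups in place of the acetate esters of compounds 2, 3 and 4.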